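The source may hold more compounds than are shown below. What is called first, only, known or untested is meant among the compounds shown, and "the series" means these compounds.

Series notes. In a functional assay on K562 cells (Homo sapiens) for antiproliferative activity, read by sulforhodamine B assay, with a stated time of 48 h, tested at 50 uM (a lower number here means less inhibition, a higher number more inhibition at the concentration tested (going by the name of the read-out)), compound 1 `CC1=CC[C@H](C(C)C)c2cc(C)c(OC(=O)Nc3ccccc3)cc21` gives 92.6%. Compound 2 `CC1=CC[C@H](C(C)C)c2cc(C)c(OC(=O)c3ccccc3)cc21` in this assay is reported only as "not active" (no number reported), with no single number behind it; the two results show that compound 1 inhibits strongly while compound 2 does not. Compound 3 `CC1=CC[C@H](C(C)C)c2cc(C)c(OC(=O)c3ccc(Cl)cc3)cc21` has not yet been tested in this assay. Compound 3 differs from compound 2 by chloro in place of hydrogen on an aromatic carbon. Among the measured compounds shown here, no number stands for compound 2, and no step to compound 3 can be sized from it. A small rise in this assay is expected, at most just beyond the scatter, and a further "not active" report is plausible. For compound 3 the estimated inhibition in this assay is 20%, within 0% to 55%.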

Compound 3, a percentage reported as inhibition, at one concentration (the size of the read-out at that concentration, not a potency): 58.9%
For compound 3 the middle estimate is 38.9 percentage points below the measured one; measured number above the stated range.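

Phenyl to 4-chlorophenyl on this carbonyl separates a "not active" report for compound 2 from a measured inhibition in this assay where compound 3 gives 58.9% at the concentration tested, so this aromatic position responds to a single chloro, though that step cannot be read as a number. Anilino still stands ahead of 4-chlorophenyl, with a number 33.7 percentage points lower from compound 1 to compound 3 (beyond the scatter) in this series. No measurement at hand bears on the reason for either difference.

Open, going by these compounds, is whether fluoro, methoxy or an amine at the same place would behave like chloro. Also open, on these data alone, is what chloro would do on the anilino ring of compound 1.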